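Notes on a cyclic amide series, cytochrome P450 11B2 inhibition

The source may hold more compounds than are shown below. What is called first, only, known or untested is meant among the compounds shown, and "the series" means these compounds.

Measured compounds:
compound 1 `CC[C@H]1c2cc(Cl)ccc2C(=O)N1c1cncc2c1CCC[C@H]2NC(C)=O` gives 97 nM
compound 2 `CCS(=O)(=O)N1CC(Oc2cncc(N3C(=O)c4ccc(Cl)cc4C3(C)C)c2)C1` gives 4 nM
compound 3 `CC(=O)N1CC[C@H](Oc2cncc(N3C(=O)c4ccc(Cl)cc4C3(C)C)c2)C1` gives 7 nM

All numbers come from an assay on cells for inhibition of cytochrome P450 11B2, mitochondrial (Homo sapiens), read by HTRF; a lower number here means a stronger inhibitor, a higher number a weaker inhibitor. Compound 3 stands second highest of the three; its nearest neighbour is compound 2, with a 1.8-fold higher number from compound 2 to compound 3 (0.24 log units; within the scatter), and the furthest is compound 1, whose number is beyond the scatter above that of compound 3.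

Compound 4 `CC1(C)c2cc(Cl)ccc2C(=O)N1c1cccnc1` is not yet measured. It differs from compound 3 by a hydrogen atom in place of a group of 9 heavy atoms (6 carbon, 1 nitrogen, 2 oxygen; one five-membered non-aromatic ring with 1 hetero atom), on an aromatic carbon. Among the compounds with values here, the only measured step, from compound 2 to compound 3, exchanges one ring-bearing group for another on the same oxygen and lies within the scatter, so it says nothing about removing the whole group. Within the data shown here, no measured pair covers a change of this kind; the estimate therefore rests on the fact that both compounds carrying a group at this place gave low numbers, and on nothing more.

Compound 4 is expected to give 120 nM in this assay, with a wide range from 15 nM to 900 nM. The expected step is a 17-fold higher number from compound 3 to compound 4 (1.23 log units; beyond the scatter).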

Compound 4, half-maximal inhibitory concentration: 108 nM
Compound 4: the middle estimate sits 1.1-fold (0.05 log units) above what was measured; low and high end bracket the measured number.
By their numbers in this assay, from the lowest: compounds 2 and 3 (each within the scatter of the next); then compounds 1 and 4 (each within the scatter of the next).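

In this assay, replacing the group of 9 heavy atoms, with its five-membered non-aromatic ring, by a hydrogen atom on the aromatic carbon gives a 15-fold higher number from compound 3 to compound 4 (1.19 log units; beyond the scatter). Within the data shown here, the exchange of one ring-bearing group for another on the same oxygen gave only a 1.8-fold higher number from compound 2 to compound 3 (0.24 log units; within the scatter), so the new step is the first to show that the number depends on having a group at this place at all. No measurement given here bears on the cause of this step.

The compounds shown leave open how much of the step belongs to the ether oxygen alone and how much to the ring and the acetyl group on it. Going by these compounds, it also remains open whether a methoxy group at this place, or an amine or a carboxylic acid on the ring, would keep the number low.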